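The compounds below may be only part of what the source reports. "The series", "measured", "known", "first", "only" and "open" are said of these compounds alone.

Measured compounds:
- Compound 1, `CNc1nccc(N2CC[C@H](NC(=O)Nc3ccc(Cl)c(C(F)(F)F)c3)C2)n1`: 99.7%
- Compound 2, `CNc1nccc(N2CC[C@H](NC(=O)Nc3ccc(CN(C)C)c(C(F)(F)F)c3)C2)n1`: 91%

Compound 1 and compound 2 share a core and were both tested in an ADME assay on a cell-free system (plasma, Rattus norvegicus) for protein binding. Compound 1 gives 99.7%, the lowest unbound fraction of the two values. For the measured compounds named here, compound 2 gives 91%, and the only measured step, a 30-fold higher unbound fraction from compound 1 to compound 2 (1.48 log units; beyond the scatter), comes from a change at the aromatic ring of the urea, where a (dimethylamino)methyl replaces a chloro.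

Compound 3, `O=C(Nc1ccc(Cl)c(C(F)(F)F)c1)N[C@H]1CCN(c2ccnc(NC3CC3)n2)C1`, is not yet measured. It differs from compound 1 at the other end of the molecule: cyclopropyl in place of methyl on a nitrogen on an aromatic ring. Going by the values given here, no measured step touches this nitrogen, so the step from compound 1 to compound 2 does not bear on it directly; it only shows how far the binding in this assay can move within this core. With nothing measured at the site of change, the expected step is small, possibly none beyond the scatter, and if anything toward a lower unbound fraction: a 1.5-fold lower unbound fraction from compound 1 to compound 3 (0.18 log units; within the scatter). Compound 3 is therefore estimated at 99.8%, with a range from 99.4% to 99.9%.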

Compound 3, plasma protein binding: 99.9%
Beside the measured number, compound 3's estimate is 2.0-fold (0.30 log units) (unbound fraction) above it, and the stated range covers the measured number.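

The result shows that the substituent on the nitrogen on an aromatic ring is not a silent position in this assay: cyclopropyl in place of methyl gives a 3.0-fold lower unbound fraction from compound 1 to compound 3 (0.48 log units; beyond the scatter). For the compounds shown here, until now the only step was at the other end of the molecule, a 30-fold higher unbound fraction from compound 1 to compound 2 (1.48 log units; beyond the scatter), so this is the first sign that the methylamino end of the shared core also moves the read-out beyond the scatter, though by a smaller step and in the opposite direction. Nothing available here explains why this exchange of methyl for cyclopropyl moves the unbound fraction in this direction.

The compounds shown leave open whether this position can also raise the unbound fraction, as an ethyl group, a longer chain ending in an amine or a chain ending in a carboxylic acid on the same nitrogen might or might not do. They also leave open whether cyclopropyl in place of methyl gives a step of similar size and direction when the (dimethylamino)methyl of compound 2 replaces the chloro.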